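The compounds below may be only part of what the source reports. "The series", "measured", "known", "first", "only" and "open" are said of these compounds alone.

Going by the values given here, in an assay on HL-60 cells for inhibition of glutathione S-transferase P (Homo sapiens), read by spectrophotometry, tested at 20 uM (a lower number here means less inhibition, a higher number more inhibition at the concentration tested (going by the name of the read-out)), compound 2 `CCOc1ccccc1/C=C1\CN(CC(=O)O)c2c(Cl)cccc2C1=O` gives 19.7%, the higher of the two numbers measured so far, while compound 1 `COc1ccccc1/C=C1\CN(CC(=O)O)c2c(C)cccc2C1=O` gives 4.72%, a gap beyond the usual scatter. Compound 3 `CCOc1ccccc1/C=C1\CN(CC(=O)O)c2c(C)cccc2C1=O` has not yet been measured in this assay. It differs from compound 2 in a single place: methyl in place of chloro on an aromatic carbon. Among the compounds with values here, no step of exactly this kind has been measured here, so its size is unknown. The expected step is a number 8.7 percentage points lower from compound 2 to compound 3 (within the scatter), a small drop. For compound 3 the estimate is 11%, with a range from 0% to 26%.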

Compound 3, a percentage reported as inhibition, at one concentration (the size of the read-out at that concentration, not a potency): 15.4%
Beside the measured number, compound 3's estimate is 4.4 percentage points below it, within the range that was stated.
By their numbers in this assay, from the lowest: compound 1; then compounds 3 and 2 (each within the scatter of the next).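

In this assay, methyl in place of chloro on the aromatic carbon is a number 4.3 percentage points lower from compound 2 to compound 3 (within the scatter) and so leaves the two groups indistinguishable at this position. Methyl in place of hydrogen on the saturated chain carbon bound to an oxygen on an aromatic ring is a number 10.7 percentage points higher from compound 1 to compound 3 (beyond the scatter) and is the one change here that clears the scatter. Nothing measured here explains either step. On these data alone, what an amine or a nitrile on that aromatic carbon would give remains open, as does whether a longer chain on the oxygen would raise the inhibition further.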